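The compounds below may be only part of what the source reports. "The series", "measured", "known", "first", "only" and "open" are said of these compounds alone.

Measured so far:
Compound 1, `CCc1cccc(NC(=O)CSc2nc(Nc3ccccc3)c3ccccc3n2)c1`: 12400 nM
Compound 2, `C=CC(=O)Nc1cccc(NC(=O)CSc2nc(Nc3ccccc3C)c3ccccc3n2)c1`: 20400 nM

Both were tested in a functional assay on MDA-MB-231 cells (Homo sapiens) for inhibition, read by MTT assay, with a stated time of 72 h; on this read-out higher numbers stand for weaker inhibition and lower numbers for stronger inhibition. Compound 2 gives the larger of the two numbers shown, but its gap to compound 1 lies within the usual scatter of repeated measurements, so on these two values the compounds cannot be told apart. Compound 3, `C=CC(=O)Nc1cccc(NC(=O)CSc2nc(Nc3ccc(Cl)cc3)c3ccccc3n2)c1`, is not yet measured. It differs from compound 2 in one place: 4-chlorophenyl in place of 2-methylphenyl on a nitrogen on an aromatic ring. Among the compounds with values here, no pair of measured compounds differs in only one place, so there is no measured step to lean on, and the two values in hand do not separate. With nothing to point to a change in either direction, the step of a 1.1-fold lower number from compound 2 to compound 3 (0.05 log units; within the scatter) is expected to fall within the scatter. Compound 3 is accordingly estimated at 18000 nM, with a likely range from 6000 nM to 55000 nM.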

Compound 3, half-maximal inhibitory concentration: 10300 nM
Estimate against measurement, compound 3: 1.7-fold (0.24 log units) above; low and high end bracket the measured number.
By their numbers in this assay, from the lowest: compounds 3, 1 and 2 (each within the scatter of the next).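

Within the data shown here, compound 3 and compound 2 give the first comparison here that differs in only one place, the group on a nitrogen on an aromatic ring, with the rest of the structure held constant. In this assay the step (a 2.0-fold lower number from compound 2 to compound 3 (0.30 log units; within the scatter)) stays within the scatter, so exchanging 2-methylphenyl for 4-chlorophenyl does not separate the two compounds. No measurement shown here offers an explanation for this result.

Going by these compounds, this single step changes both the atom on the phenyl ring and its place on that ring, so the contribution of each remains unknown. Also open, on these data alone, is whether a phenyl ring carrying an amine or a carboxylic acid, or a longer chain in place of the phenyl ring, would give a step beyond the scatter.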